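The source may hold more compounds than are shown below. What is called first, only, known or untested is meant among the compounds shown, and "the series" means these compounds.

Measured so far:
Compound 1, `CO[C@@]12CCN(C)C[C@H]1[C@H](c1ccc(Br)cc1)C(C#N)=C(N)O2`, in a functional assay on trachea (Cavia porcellus) (on this read-out higher numbers stand for weaker inhibition and lower numbers for stronger inhibition), compound 1 gives 7900 nM.
Compound 2, `CCCN1CC[C@@]2(OC)OC(N)=C(C#N)[C@@H](c3ccc(Br)cc3)[C@@H]2C1`, in this assay compound 2 gives 19400 nM.

Going by the values given here, compound 2 stands at the highest of the two numbers, and its only neighbour is compound 1; the step is a 2.5-fold higher number from compound 1 to compound 2 (0.39 log units; beyond the scatter), a change confined to the chain on the ring amine nitrogen.

Compound 3, `CCCN1CC[C@@]2(OC)OC(N)=C(C#N)[C@@H](c3ccc(Cl)cc3)[C@@H]2C1`, has not been measured. It differs from compound 2 in one place: chloro in place of bromo on an aromatic carbon. Among the compounds with values here, none of the measured steps touches this part of the molecule. Within the data shown here, the single step that exists, a 2.5-fold higher number from compound 1 to compound 2 (0.39 log units; beyond the scatter), concerns the ethyl on the chain carbon bound to the amine nitrogen and says nothing about the substituent on the aromatic ring. The expectation for compound 3 therefore rests on the change itself, an exchange of one halogen for another at the same position, which usually shifts such numbers little; compound 3 is expected to sit close to compound 2, with a step of a 1.1-fold higher number from compound 2 to compound 3 (0.05 log units; within the scatter) that may well lie within the scatter.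

The estimate for compound 3 is 22000 nM, in a range from 8000 nM to 70000 nM.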

Compound 3, half-maximal inhibitory concentration: 30300 nM
Compound 3: the middle estimate sits 1.4-fold (0.14 log units) below what was measured, and the stated range covers the measured number.
By their numbers in this assay, from the lowest: compound 1; then compounds 2 and 3 (each within the scatter of the next).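

In this assay, chloro in place of bromo on the aromatic carbon gives a 1.6-fold higher number from compound 2 to compound 3 (0.19 log units; within the scatter), so the 4-bromophenyl and 4-chlorophenyl forms of the shared core cannot be told apart on this read-out. Going by these compounds alone, this is the first information about this position, since the only earlier step, a 2.5-fold higher number from compound 1 to compound 2 (0.39 log units; beyond the scatter), concerned the chain on the ring amine nitrogen; it shows that, with the propyl chain in place, one halogen can stand in for the other here without a change beyond the usual scatter. Nothing at hand gives a reason for the small difference between the two halogens, or shows whether it is real.

With only bromo and chloro shown, this position has been sampled very narrowly, and it remains open how the number would respond to a fluoro, a methoxy, an amine or a carboxylic acid on the same aromatic carbon, or to a phenyl carrying no substituent there. From the compounds shown here alone, it also remains open whether the exchange of halogens would read the same with the shorter chain of compound 1 on the ring amine nitrogen.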